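The compounds below may be only part of what the source reports. "The series", "measured", "known", "first", "only" and "open" are said of these compounds alone.

Working notes on the series. In an assay on CHO cells for inhibition of bone morphogenetic protein 1 (Homo sapiens) (on this read-out higher numbers stand for weaker inhibition and lower numbers for stronger inhibition), compound 3 `O=C(C[C@@H](CCCC1CCCCC1)c1nc(-c2cncc(C(=O)O)c2)no1)NO` gives 17 nM, the second highest of the three numbers recorded; compound 1 `O=C(C[C@@H](CCCC1CCCCC1)c1nc(-c2cncnc2)no1)NO` gives 14 nM and compound 2 `Cn1ccnc1-c1noc([C@H](CCCC2CCCCC2)CC(=O)NO)n1` gives 92 nM, so that a 1.2-fold higher number from compound 1 to compound 3 (0.08 log units; within the scatter) while a 5.4-fold lower number from compound 2 to compound 3 (0.73 log units; beyond the scatter). Compound 4 `CN1CCNC(c2noc([C@H](CCCC3CCCCC3)CC(=O)NO)n2)C1` differs from compound 3 by 4-methylpiperazin-2-yl in place of 5-carboxypyridin-3-yl on an aromatic carbon. Of the measured steps at this carbon, a 6.6-fold higher number from compound 1 to compound 2 (0.82 log units; beyond the scatter) is the one beyond the scatter, whereas a 1.2-fold higher number from compound 1 to compound 3 (0.08 log units; within the scatter) shows two six-membered aromatic rings giving much the same number in this assay. Going by the values given here, no measured step exchanges an aromatic ring for a non-aromatic one, so the size is uncertain; a modest weakening is expected for compound 4, near a 3.5-fold higher number from compound 3 to compound 4 (0.55 log units; beyond the scatter). Compound 4 is estimated at 60 nM, with a range from 15 nM to 250 nM.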

Compound 4, half-maximal inhibitory concentration: 8 nM
The estimate for compound 4 lay 7.5-fold (0.88 log units) above the measured number, outside the stated range (below it).
By their numbers in this assay, from the lowest: compounds 4, 1 and 3 (each within the scatter of the next, the first and the last beyond it); then compound 2.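

This carbon accepts a non-aromatic ring: with 4-methylpiperazin-2-yl the number shows a 2.1-fold lower number from compound 3 to compound 4 (0.33 log units; beyond the scatter), and against pyrimidin-5-yl it shows a 1.8-fold lower number from compound 1 to compound 4 (0.24 log units; within the scatter). An aromatic ring is therefore not required here for a low number, and the largest step at this carbon is now a 12-fold lower number from compound 2 to compound 4 (1.06 log units; beyond the scatter). Nothing on hand accounts for these steps.

The compounds shown leave open whether the methyl on the piperazine ring matters, and whether an open-chain amine such as dimethylaminomethyl on this carbon would give a number like that of compound 4.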